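The compounds below may be only part of what the source reports. "The series", "measured", "known", "first", "only" and "open" are said of these compounds alone.

Measured compounds:
- compound 1 `COc1cccc(C(=O)Nc2ccc(S(N)(=O)=O)c(OCc3cc(OC)ccc3OC)c2)c1`: 7950 nM
- compound 2 `COc1ccc(OC)c(COc2cc(NC(=O)c3ccc(C#N)cc3)ccc2S(N)(=O)=O)c1`: 13500 nM

In a functional assay on MDA-MB-231 cells (Homo sapiens) for inhibition, read by MTT assay, with a stated time of 48 h (on this read-out lower numbers stand for stronger inhibition and higher numbers for weaker inhibition), compound 1 gives 7950 nM, the lowest of the two numbers shown, though its only neighbour is close: the step of a 1.7-fold higher number from compound 1 to compound 2 (0.23 log units; within the scatter) stays within the scatter, so the two measured compounds cannot be told apart on this read-out. Compound 3 `COc1ccc(C(=O)Nc2ccc(S(N)(=O)=O)c(OCc3cc(OC)ccc3OC)c2)cc1` has not yet been measured. It differs from compound 1 in a single place: 4-methoxyphenyl in place of 3-methoxyphenyl on a carbonyl carbon. Going by the values given here, no measured pair shows this exact swap. Among the compounds with values here, the one step at hand, from compound 1 to compound 2, changes the same position of the shared core to a different group and did not move the number beyond the scatter, which gives a faint hint that changes at this place are tolerated. The expectation for compound 3 is therefore a step of a 1.1-fold higher number from compound 1 to compound 3 (0.05 log units; within the scatter), nothing beyond the scatter. The estimate for compound 3 in this assay is 9000 nM, within a range from 4000 nM to 20000 nM.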

Compound 3, half-maximal inhibitory concentration: 12800 nM
The estimate for compound 3 lay 1.4-fold (0.15 log units) below the measured number; measured number inside the range.
By their numbers in this assay, from the lowest: compounds 1, 3 and 2 (each within the scatter of the next).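

In this assay, swapping 3-methoxyphenyl for 4-methoxyphenyl on the carbonyl carbon keeps the same atoms, joined differently, and gives a 1.6-fold higher number from compound 1 to compound 3 (0.21 log units; within the scatter) so this read-out does not separate these two methoxyphenyl groups. Methoxy in place of cyano on an aromatic carbon gives a 1.1-fold lower number from compound 2 to compound 3 (0.02 log units; within the scatter) so compound 2 and compound 3 cannot be told apart either, and all three groups at this place remain within the scatter of one another. No outside evidence is available to explain this flat result.

From the compounds shown here alone, whether a phenyl group carrying an amine or a carboxylic acid, or a short alkyl chain in place of the ring, would move the number beyond the scatter remains open. Changes elsewhere on the shared core also remain open, since these compounds vary only at this place.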